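The source may hold more compounds than are shown below. What is called first, only, known or untested is meant among the compounds shown, and "the series" means these compounds.

Measured so far in a functional assay (aorta) with Rattus norvegicus as the target; a higher number here means a weaker inhibitor, a lower number a stronger inhibitor: compound 1 `C/N=C(/S)C1(c2cccnc2)CCCCC1=O` gives 800 nM; compound 2 `C/N=C(/S)[C@@]1(c2cccnc2)CCCC[C@@H]1CCO` gives 1700 nM; compound 3 `CNC(=S)[C@@]1(c2cccnc2)CCCC[C@@H]1CCNS(=O)(=O)c1ccc(OC)cc1` gives 300 nM.

Compound 2 stands at the highest of the three numbers in this assay. Compound 1 sits lower by a margin beyond the scatter, and compound 3 lies lower still, also beyond the scatter. Compound 4 `C/N=C(/S)[C@@]1(c2cccnc2)CCCC[C@@H]1CCNC(C)=O` has not yet been measured. It differs from compound 2 by acetamido in place of hydroxy on a saturated chain carbon, two bonds along the chain from a saturated ring carbon. Going by the values given here, no step between measured compounds is available for this change, so its size is uncertain. Since compound 3 carries a larger group on that chain and gives 300 nM, a downward step is expected. The step from compound 2 to compound 4 is expected to be a 1.9-fold lower number from compound 2 to compound 4 (0.28 log units; within the scatter), beyond the scatter. Compound 4 is estimated at 900 nM, within 300 nM to 2500 nM.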

Compound 4, concentration for 90% inhibition: 130 nM
For compound 4 the middle estimate is 6.9-fold (0.84 log units) above the measured one, outside the stated range (below it).
By their numbers in this assay, from the lowest: compound 4; then compound 3; then compound 1; then compound 2.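

In this assay, acetamido in place of hydroxy on a saturated chain carbon, two bonds along the chain from a saturated ring carbon, gives a 13-fold lower number from compound 2 to compound 4 (1.12 log units; beyond the scatter) and so shows that this single change can produce a large step. The counts of hydrogen-bond donors and acceptors are the same for both groups, so those counts do not separate compound 2 from compound 4. Nothing shown here accounts for the size of the step.

The compounds shown leave open how an amine at this place, or a longer chain carrying acetamido, would compare with compound 4.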